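This account rests on a few compounds, and the source may have more. Where it says the series, first, only, none or still open, it means among the compounds named here.

Measured so far in an assay on 3T3-L1 cells for inhibition of diacylglycerol O-acyltransferase 1 (Mus musculus); on this read-out lower numbers stand for stronger inhibition and higher numbers for weaker inhibition:
Compound 1 `Cc1cc(NC(=O)c2ccc3ccccc3c2)ccc1-c1cnc(OCC(C)(C)C(=O)O)cn1` — 2160 nM.
Compound 2 `CCC(Sc1nnc(-c2ccc(NC(=O)c3ccc(Cl)c(Cl)c3)cc2)n1C)C(=O)O` — > 20000 nM, a limit of this assay rather than a number.
Compound 3 `Cc1ccccc1C(=O)Nc1ccc(-c2nnc(SC(C)C(=O)O)n2C)cc1` — > 20000 nM, likewise a limit and not a number.

Compound 3 thus stands at the bottom of the shown range, where (the limit of > 20000 nM in this assay, at which 2 of the 3 values shown sit); only compound 1 gives a numeric value. Compound 4 `Cc1ccc(C(=O)Nc2ccc(-c3nnc(SC(C)C(=O)O)n3C)cc2)cc1` differs from compound 3 by 4-methylphenyl in place of 2-methylphenyl on a carbonyl carbon. Among the compounds with values here, no measured pair tracks this change, so no step is known for it. Since compound 3 sits at a limit, any step in this assay from compound 3 to compound 4 can only be resolved if compound 4 gains potency; the expectation is a modest gain at most, an at least 1.3-fold lower number from compound 3 to compound 4 (0.12 log units; that floor lies within the scatter), likely within scatter. Compound 4 is estimated at 15000 nM, range 4000 nM to 40000 nM.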

Compound 4, half-maximal inhibitory concentration: > 20000 nM
Compound 4: no number, only a limit (the forecaster's own chance of this, stated with the estimate: 55%); middle value at least 1.3-fold (0.12 log units) away from the limit.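

Compound 3 and compound 4 both sit at a limit, not a number, so no step can be read between them: the limit of > 20000 nM in this assay, at which 3 of the 4 values shown sit.

The compounds shown leave open whether 4-methylphenyl in place of 2-methylphenyl changes inhibition at all.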